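The source may report more compounds than this note shows. Statements on the series, on what has been measured and on what is new or still open speak of the compounds shown alone.

Measured so far:
compound 1 `O=C(/C=C/CNCCOc1ccc(Oc2c(-c3ccc(F)cc3)sc3cc(O)ccc23)cc1)N1CCCC1` — 7610 nM
compound 2 `C=CC(=O)N1CC(Oc2ccc(Oc3c(-c4ccc(F)cc4)sc4cc(O)ccc34)cc2)C1` — 23500 nM
compound 3 `CNC(=O)/C=C/CN1CC(Oc2ccc(Oc3c(-c4ccc(F)cc4)sc4cc(O)ccc34)cc2)C1` — > 25000 nM

All three were read in a functional assay on MCF7 cells (Homo sapiens) for antiproliferative activity, read by CCK-8 assay, with a stated time of 48 h; a lower number here means a stronger inhibitor, a higher number a weaker inhibitor. Compound 1 gives 7610 nM and compound 2 gives 23500 nM. For compound 3 this assay reports only a limit, > 25000 nM, and no number. Compound 3 is the single case at the limit of > 25000 nM in this assay, at which 1 of the 3 values shown sits, so it stands at the weak end of the set without a fixed position. Among the compounds with values here, the only step in one place, an at least 1.0-fold higher number from compound 2 to compound 3 (0.02 log units; that floor lies within the scatter), lies within the scatter.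

Compound 4 `CN(C)C(=O)/C=C/CNCCOc1ccc(Oc2c(-c3ccc(F)cc3)sc3cc(O)ccc23)cc1` is the next to be measured in this assay. It differs from compound 3 by 2-((3-(dimethylcarbamoyl)prop-2-en-1-yl)amino)ethyl in place of 1-(3-(methylcarbamoyl)prop-2-en-1-yl)azetidin-3-yl on an oxygen on an aromatic ring. Within the data shown here, no measured step covers this change directly; the closest reference is compound 1, which carries the open-chain ethyl linker and gives 7610 nM, while the four-membered ring compounds sit higher. The expectation is therefore a step toward lower numbers from compound 3 to compound 4, of the size an at least 2.7-fold lower number from compound 3 to compound 4 (0.44 log units; beyond the scatter). Compound 4 is estimated at 9000 nM, in a range from 3000 nM to 25000 nM.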

Compound 4, half-maximal inhibitory concentration: 13800 nM
The estimate for compound 4 lay 1.5-fold (0.19 log units) below the measured number; the measured number falls inside the stated range.
By their numbers in this assay, from the lowest: compounds 1, 4 and 2 (each within the scatter of the next, the first and the last beyond it). At a limit, above all of these: compound 3.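

In this assay, 2-((3-(dimethylcarbamoyl)prop-2-en-1-yl)amino)ethyl in place of 1-(3-(methylcarbamoyl)prop-2-en-1-yl)azetidin-3-yl on an oxygen on an aromatic ring gives an at least 1.8-fold lower number from compound 3 to compound 4 (0.25 log units; that floor lies within the scatter). Compound 3 carries a limit and no number, so that step is only a floor: the limit of > 25000 nM in this assay, at which 1 of the 4 values shown sits. The steps of a 1.7-fold lower number from compound 2 to compound 4 (0.23 log units; within the scatter) and a 1.8-fold higher number from compound 1 to compound 4 (0.26 log units; within the scatter) stay within the scatter, so neither the exchange for 1-(vinylcarbonyl)azetidin-3-yl nor dimethylamino in place of pyrrolidin-1-yl on a carbonyl carbon separates measurably here.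

The exchange from compound 3 to compound 4 opens the ring and alters the amide together, so the compounds shown do not divide the two contributions. As far as these compounds go, whether a longer chain on that oxygen, a piperidine ring in place of the four-membered ring, or a morpholine amide would move the number beyond the scatter stays open.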